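Methylating the thiol sulfur: what compound 3 might do

A few compounds are considered here, and "the series" means these few. Any claim that something is new, unique, unknown or untested is made for them only; others in the source may bear on it.

Compound 1, `CS(=O)(=O)N1CC(CCl)c2ccc(N)cc21`, is the stronger of the two measured compounds in a functional assay on EMT6 cells (Mus musculus) for cytotoxicity, with a stated time of 4 h (a higher number here means a weaker inhibitor, a lower number a stronger inhibitor), where compound 1 gives 33000 nM. Compound 2, `CS(=O)(=O)N1CC(CCl)c2ccc(S)cc21`, differs from it by a sulfanyl in place of the amino group on the aromatic carbon. In this assay compound 2 reaches only a limit, > 200000 nM, which is not a number but the edge of what the measurement reports. The change is an at least 6.0-fold higher number from compound 1 to compound 2 (0.78 log units; beyond the scatter), and the size is known only as a lower bound because of the limit of > 200000 nM in this assay, at which 1 of the 2 values shown sits. Compound 2 therefore stands at the weak end of everything measured here.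

Compound 3, `CSc1ccc2c(c1)N(S(C)(=O)=O)CC2CCl`, is made from compound 2 by methyl in place of hydrogen on a sulfur. Going by the values given here, no measured step touches this sulfur, so the single known step offers no direct guide. The expectation is a step that the limit leaves unreadable from compound 2 to compound 3, with compound 3 most likely again only a limit. Compound 3 is estimated at 300000 nM, ranging from 100000 nM to 1000000 nM.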

Compound 3, half-maximal inhibitory concentration: > 200000 nM
Compound 3 was reported as a limit; the forecaster's own chance of this, stated with the estimate: 70%; the middle value lies beyond the limit too.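

In this assay compound 3 gives > 200000 nM, which is a limit and not a number. Putting methylsulfanyl in place of the amino group gives an at least 6.0-fold higher number from compound 1 to compound 3 (0.78 log units; beyond the scatter), so neither sulfur group on this aromatic carbon matches the amino group of compound 1, whether the sulfur carries a hydrogen or a methyl. The step from compound 2 to compound 3 cannot be read because both compounds sit at the same limit: the limit of > 200000 nM in this assay, at which 2 of the 3 values shown sit.

Going by these compounds, how far compound 2 and compound 3 really lie from compound 1 stays open, as does whether the methyl on the sulfur changes anything at all. The compounds shown also leave open whether a hydroxyl, a methylamino group or a carboxylic acid on this aromatic carbon would come closer to the amino group.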